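Chain variation on the triazolyl-bicyclooctane series

The source may hold more compounds than are shown below. What is called first, only, known or untested is meant among the compounds shown, and "the series" means these compounds.

Of the compounds shown here, three of the shared core have been measured in a functional assay on the whole organism (strain ICR) for inhibition, with Mus musculus as the target, with a stated time of 4 h, at a dose of 10 mg/kg by the oral route; a higher number here means more inhibition at the dose given (going by the name of the read-out), a lower number less inhibition. Compound 1 `CCS(=O)(=O)CCC12CCC(c3nnc(-c4ccccc4C)n3C)(CC1)CC2` gives 86%, and compound 3 `CCS(=O)(=O)CCC12CCC(c3nnc(-c4ccccc4Br)n3C)(CC1)CC2` gives 86%; the step of no change at the digits printed from compound 1 to compound 3 (within the scatter) shows that exchanging the aromatic substituent left the read-out unchanged. Compound 2 `Cn1c(-c2ccccc2C(F)(F)F)nnc1C12CCC(CNS(C)(=O)=O)(CC1)CC2` gives 73%, the lowest of the three numbers, standing below both compound 1 and compound 3 by a gap beyond the scatter.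

Compound 4 `CC(O)CCCC12CCC(c3nnc(-c4ccccc4C(F)(F)F)n3C)(CC1)CC2` is not yet measured. Its difference from compound 2 is 3-hydroxybutyl in place of methanesulfonamido on a saturated chain carbon bound to a saturated ring carbon. Among the measured compounds shown here, no measured pair changes the chain at this position, so the only step in hand, from compound 1 to compound 3, concerns the aromatic substituent and does not bear directly on this change. Compound 4 keeps the trifluoromethyl aryl of compound 2, so compound 2 is the nearest reference. A modest step of a number 4 percentage points higher from compound 2 to compound 4 (within the scatter) is expected, with wide uncertainty. Compound 4 is therefore estimated at 77%, within 58% to 92%.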

Compound 4, a percentage reported as inhibition, in the whole organism at one dose (the size of the read-out at that dose, not a potency): 97%
Compound 4: middle estimate off by 20 percentage points, on the low side; the whole stated range lies below it.
By their numbers in this assay, from the lowest: compound 2; then compounds 1 and 3 (each within the scatter of the next); then compound 4.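

Among the compounds shown here, the chain on the saturated ring carbon is not neutral in this assay: with the trifluoromethyl aryl held fixed, the change to 3-hydroxybutyl from methanesulfonamido gives a number 24 percentage points higher from compound 2 to compound 4 (beyond the scatter) and is the first reading at this position, as the earlier pair spoke only to the aromatic substituent. The two groups match in their counts of heavy atoms and hydrogen-bond donors, so neither count tracks this step; they differ in atom makeup and in hydrogen-bond acceptors, but a single pair cannot separate these. No measurement in hand explains the step.

On these data alone, whether the hydroxyl itself contributes stays open, and a plain pentyl chain, an amine or a carboxylic acid at this position would test that. Also open, as far as these compounds go, is whether the step carries over to the methyl or bromo aryl of compounds 1 and 3.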